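The source may report more compounds than this note shows. Statements on the series, on what has been measured and on what is new or still open speak of the compounds shown alone.

Measured compounds:
compound 1 `COc1ccc(C2SCC(=O)N2CCN2CCCCC2)cc1` — 89%
compound 2 `O=C1CSC(c2ccc([N+](=O)[O-])cc2)N1CCN1CCCCC1` — 87%
compound 3 `COc1ccccc1C1SCC(=O)N1CCN1CCCCC1` — 100%

All three were read in an ADME assay on Vero cells (Chlorocebus sabaeus) for cytotoxicity, read by neutral red uptake, tested at 98 ug/mL; on this read-out higher numbers stand for a weaker effect at the one concentration tested and lower numbers for a stronger effect. For the measured compounds named here, compound 1 and compound 2 give values within the scatter of each other; the step of a number 2 percentage points lower from compound 1 to compound 2 (within the scatter) is the first example of the change (nitro in place of methoxy on an aromatic carbon). Compound 3 stands highest of the three numbers, beyond the scatter from both compound 1 and compound 2. The difference between the core of compound 3 and the core of compound 1 is not broken down here.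

Compound 4 `O=C1CSC(c2ccccc2[N+](=O)[O-])N1CCN1CCCCC1` is not yet measured. It differs from compound 3 by nitro in place of methoxy on an aromatic carbon. Going by the values given here, this is the same kind of change as the one from compound 1 to compound 2, but the place differs: there the group sits para to a large group, here ortho to a large group. Among the compounds with values here, only one measured example exists, so the expectation rests on that single step a number 2 percentage points lower from compound 1 to compound 2 (within the scatter) and on the value of compound 3 100% in this assay. The step from compound 3 to compound 4 in this assay is expected to be a number 3 percentage points lower from compound 3 to compound 4 (within the scatter), roughly like the earlier one. Compound 4 is estimated at 97%, between 85% and 100%.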

Compound 4, a percentage reported as activity, at one concentration (the size of the read-out at that concentration, not a potency): 100%
For compound 4 the middle estimate is 3 percentage points below the measured one, within the range that was stated.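

In this assay, nitro in place of methoxy on an aromatic carbon has now been read on two cores, and the two steps do not differ: the same change on two cores in this assay, a number 2 percentage points lower (within the scatter) from compound 1 to compound 2 and no change at the digits printed (within the scatter) from compound 3 to compound 4, 2 percentage points apart, within the scatter of two such steps. The new pair shows no change at the digits printed from compound 3 to compound 4 (within the scatter), so with the group ortho to a large group the change again leaves the read-out within the scatter. This does not show that the change is neutral on other cores or at other concentrations, since the evidence is two pairs read at one concentration, and the two pairs differ in where the group sits, so core and place cannot be told apart.

The compounds shown leave open whether a carboxylic acid, an amine or a fluorine atom in the same place would also give a step within the scatter. They also leave open what either group does at other places on the aromatic ring.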